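A few compounds are considered here, and "the series" means these few. Any claim that something is new, unique, unknown or untested is made for them only; others in the source may bear on it.

Going by the values given here, compound 2, `CNC(=O)c1cc(Oc2ccc(C(=O)/C=C/c3ccc(C#N)cc3)cc2)ccn1`, is the only compound among those measured here to give a number in a functional assay on HepG2 cells (Homo sapiens) for cytotoxicity, read by MTT assay, with a stated time of 72 h (on this read-out higher numbers stand for weaker inhibition and lower numbers for stronger inhibition), where compound 2 gives 5430 nM. Compound 1, `CNC(=O)c1cc(Oc2ccc(/C=C/C(=O)c3ccc(C)cc3)cc2)ccn1`, is recorded only as a limit, > 50000 nM, in this assay; (the limit of > 50000 nM in this assay, at which 1 of the 2 values shown sits). Compound 3, `CNC(=O)c1cc(Oc2ccc(C(=O)/C=C/c3ccc(F)cc3)cc2)ccn1`, is not yet measured. It differs from compound 2 by fluoro in place of cyano on an aromatic carbon. Among the compounds with values here, with no measured step of this kind to lean on, compound 3 is expected to move only slightly from compound 2, if at all, by a 1.5-fold higher number from compound 2 to compound 3 (0.17 log units; within the scatter) in this assay. Compound 3 is therefore estimated at 8000 nM, within a range from 3000 nM to 25000 nM.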

Compound 3, half-maximal inhibitory concentration: 12600 nM
The estimate for compound 3 lay 1.6-fold (0.20 log units) below the measured number; low and high end bracket the measured number.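

In this assay, going by these compounds alone, the change from 4-cyanophenyl to 4-fluorophenyl provides the only measured step at this position: a 2.3-fold higher number from compound 2 to compound 3 (0.37 log units; beyond the scatter). The group on this aromatic carbon, para to a large group, therefore affects the read-out, although only modestly, and both compounds still give numbers rather than a limit. Nothing shown here accounts for the step. From the compounds shown here alone, it remains open how chloro, methoxy or an amine at the same place would read in this assay, and whether any of them would give a lower number than the nitrile of compound 2.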